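The compounds below may be only part of what the source reports. "The series", "measured", "known", "first", "only" and "open" are said of these compounds alone.

In an ADME assay on MT4 cells (Homo sapiens) for cytotoxicity, read by MTT assay, with a stated time of 4 days (on this read-out higher numbers stand for lower toxicity in this test and lower numbers for higher toxicity in this test), compound 1 (`O=C(COc1cccc2ccccc12)N/N=C/c1ccc(Cl)cc1`) gives 87.6 ug/mL as its reading and compound 2 (`O=C(COc1cccc2ccccc12)N/N=C/c1cccc(Br)c1`) gives 87.4 ug/mL on the same read-out, so the two stand level. Compound 3 (`O=C(COc1cccc2ccccc12)N/N=C/c1ccc(F)cc1`) keeps the shared core and differs from compound 2 at one place (4-fluorophenyl in place of 3-bromophenyl on a carbon with a double bond to nitrogen), with 4-fluorophenyl in place of 3-bromophenyl on a carbon with a double bond to nitrogen. Among the compounds with values here, only one measured step bears on this, a swap of groups at that same place. That step, a 1.0-fold lower number from compound 1 to compound 2 (0.00 log units; within the scatter) as measured, lies within the scatter. Within the data shown here, it is a single pair, and no compound carrying fluorine has yet been measured, so the evidence is thin. The step expected is a 1.0-fold lower number from compound 2 to compound 3 (0.01 log units; within the scatter) and thus none beyond the scatter, in neither direction. Compound 3 is estimated at 85 ug/mL with 40 ug/mL to 140 ug/mL as the expected span.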

Compound 3, half-maximal cytotoxic concentration: 65.1 ug/mL
Beside the measured number, compound 3's estimate is 1.3-fold (0.12 log units) above it, within the range that was stated.
By their numbers in this assay, from the lowest: compounds 3, 2 and 1 (each within the scatter of the next).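

In this assay, the change on the carbon with a double bond to nitrogen now extends to a fluorine-bearing phenyl group, and a 1.3-fold lower number from compound 2 to compound 3 (0.13 log units; within the scatter) shows that this swap stays within the scatter, as does the narrower swap of fluoro in place of chloro on an aromatic carbon, a 1.3-fold lower number from compound 1 to compound 3 (0.13 log units; within the scatter). Across the 4-chlorophenyl, 3-bromophenyl and 4-fluorophenyl groups, then, this read-out does not separate compound 1, compound 2 and compound 3, and none of the three goes against that. No measurement shown gives a cause for these readings.

Still open, from the compounds shown here alone, is whether a phenyl group carrying an amine or a carboxylic acid at this place would stay level with these three. The same holds for an unsubstituted phenyl group or a longer chain in its stead.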